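From 2-hydroxyethyl to 3-hydroxypropyl on a Shared Core

The compounds below may be only part of what the source reports. "The series", "measured", "known", "first", "only" and "open" are said of these compounds alone.

In an ADME assay on L6 cells (Rattus norvegicus) for cytotoxicity, read by fluorescence, with a stated time of 72 h (a higher number here means a weaker inhibitor, a lower number a stronger inhibitor), compound 1 `OCCNc1ccnc2cc(Cl)ccc12` gives 233000 nM, the higher of the two numbers available. Compound 3 `COc1cc(NC(C)CCCNC(c2ccc(CO[C@@H]3COc4nc([N+](=O)[O-])cn4C3)cc2)c2nnnn2C(C)(C)C)c2ncccc2c1` gives 75900 nM, a lower number by a margin beyond the scatter. For compound 2 `O=Cc1ccc(CO[C@@H]2COc3nc([N+](=O)[O-])cn3C2)cc1`, the entry reads "not determined" (no result reported), so it offers no comparison.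

The next compound to be tested, compound 4 `OCCCNc1ccnc2cc(Cl)ccc12`, differs from compound 1 in a single place: hydroxymethyl in place of hydroxy on a saturated chain carbon, two bonds along the chain from a nitrogen on an aromatic ring. It carries hydroxymethyl in place of hydroxy on a saturated chain carbon, two bonds along the chain from a nitrogen on an aromatic ring, which turns (2-hydroxyethyl)amino into (3-hydroxypropyl)amino. Going by the values given here, no measured pair in this set shows a change of this kind, so the expectation rests only on how small the change is. The expected step in this assay, a 1.2-fold lower number from compound 1 to compound 4 (0.07 log units; within the scatter), is slightly downward and is estimated to stay within the scatter. For compound 4, the estimated value is 200000 nM, with an expected range of 90000 nM to 400000 nM.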

Compound 4, half-maximal inhibitory concentration: 178000 nM
Beside the measured number, compound 4's estimate is 1.1-fold (0.05 log units) above it, and the stated range covers the measured number.
By their numbers in this assay, from the lowest: compound 3; then compounds 4 and 1 (each within the scatter of the next).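

Hydroxymethyl in place of hydroxy on a saturated chain carbon, two bonds along the chain from a nitrogen on an aromatic ring, gives a 1.3-fold lower number from compound 1 to compound 4 (0.12 log units; within the scatter) in this assay, so the change from (2-hydroxyethyl)amino to (3-hydroxypropyl)amino does not separate the two compounds in this read-out. Going by these compounds alone, this is the first pair in the set that differ in one place, and thus the first direct reading of this position, which the separate values of the earlier compounds could not give. No independent evidence bears on this result.

The compounds shown leave open whether a longer chain ending in hydroxy, or a chain ending in an amine or a carboxylic acid, would also stay within the scatter of compound 1. This single pair also cannot show whether the same change would behave alike on another core.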